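A few compounds are considered here, and "the series" means these few. Any claim that something is new, unique, unknown or untested is made for them only; others in the source may bear on it.

Measured compounds:
Compound 1 `O=C(CN(c1nc(Cl)nc2[nH]cnc12)C1CC1)N[C@@H](CO)C(=O)OCc1ccccc1` gives 34.5% in a functional assay on the whole organism (Tail, strain ICR) with Mus musculus as the target, in the tail flick test, with a stated time of 120 min, at a dose of 25 umol/kg by the oral route; on this read-out higher numbers stand for a stronger effect at the one dose given and lower numbers for a weaker effect.
Compound 2 `O=C(CN(c1nc(Cl)nc2[nH]cnc12)C1CC1)N[C@@H](CO)C(=O)O` gives 39% in this assay.
Compound 3 `CC(C)(C)OC(=O)NCCCC[C@H](NC(=O)CN(c1ncnc2c1ncn2C1CCCCO1)C1CC1)C(=O)OCc1ccccc1` gives 28.4% in this assay.

Compound 1 holds the second highest of the three numbers, yet its distance to compound 2 and its distance to compound 3 both fall within the usual scatter of this kind of measurement, so the three compounds cannot be ranked on these numbers. Going by the values given here, the only single-place step measured is a number 4.5 percentage points higher from compound 1 to compound 2 (within the scatter), a change at the ester oxygen, and it stayed within the scatter.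

Compound 4 `NC(=O)CC[C@H](NC(=O)CN(c1nc(Cl)nc2[nH]cnc12)C1CC1)C(=O)OCc1ccccc1` differs from compound 1 by carbamoylmethyl in place of hydroxy on a saturated chain carbon, two bonds along the chain from an amide-type nitrogen and a carbonyl carbon. Among the compounds with values here, no measured step touches this part of the molecule, so the side chain change has no direct precedent here. Within the data shown here, what the data do show is that the one step measured moved nothing beyond the scatter, and that three compounds with varied side chains and cores gave closely grouped numbers. The expected step is therefore a number 0.5 percentage points lower from compound 1 to compound 4 (within the scatter), nothing beyond the scatter. For compound 4 the estimate is 34%, within a range from 20% to 48%.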

Compound 4, a percentage reported as activity, at one dose (the size of the read-out at that dose, not a potency): 36%
Beside the measured number, compound 4's estimate is 2 percentage points below it, within the range that was stated.
By their numbers in this assay, from the lowest: compounds 3, 1, 4 and 2 (each within the scatter of the next, the first and the last beyond it).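

In this assay, replacing hydroxymethyl with 2-carbamoylethyl on this saturated chain carbon gives a number 1.5 percentage points higher from compound 1 to compound 4 (within the scatter). Going by these compounds alone, this is the first reading at this position, which the earlier step at the ester oxygen did not touch, and it shows that this larger side chain, with its terminal amide, leaves the effect at this single dose indistinguishable from that of compound 1. Nothing available explains why the read-out holds across this change.

One change cannot show whether this position accepts other groups as well, so a side chain ending in a free amine or a carboxylic acid remains an open test. From the compounds shown here alone, it is also open whether a longer chain would leave the number inside the scatter, or whether a change of this kind would move it beyond.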